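Exchanging the Methoxyphenyl Arm for a Dichlorophenyl Arm

The source may hold more compounds than are shown below. What is called first, only, known or untested is meant among the compounds shown, and "the series" means these compounds.

Compound 2 `COc1ccc(-c2c(-c3ccc(S(C)(=O)=O)cc3)oc3ccccc3c2=S)cc1` stands at the floor of an assay on isolated protein for inhibition of prostaglandin G/H synthase 1 (Mus musculus), tested at 10 ug/mL; a lower number here means less inhibition, a higher number more inhibition at the concentration tested (going by the name of the read-out): in this assay compound 2 gives < 5%, which is a limit of the assay and not a number. Its two neighbours share that position. Compound 1 `CS(=O)(=O)c1ccc(-c2oc3ccccc3c(=S)c2-c2ccc(F)cc2)cc1` gives < 5% in this assay, again a limit. Compound 3 `CS(=O)(=O)c1ccc(-c2oc3ccccc3c(=O)c2-c2ccc(Cl)cc2)cc1` gives < 5% in this assay, also a limit. For the measured compounds named here, the one step measured in a single place, a step that the two limits leave unreadable from compound 1 to compound 2, rests on two limits and so its size cannot be read; the limit of < 5% in this assay, at which 3 of the 3 values shown sit, records that every value shown sits there.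

Compound 4 `CS(=O)(=O)c1ccc(-c2oc3ccccc3c(=S)c2-c2ccc(Cl)c(Cl)c2)cc1` differs from compound 2 by 3,4-dichlorophenyl in place of 4-methoxyphenyl on an aromatic carbon. No readable step bears on this exchange, and the one that touches the same position is itself unreadable. With all three measured compounds at the limit, the step that the limit leaves unreadable from compound 2 to compound 4 is expected to be none beyond the scatter. Compound 4 is therefore estimated at 3% in this assay, within a range from 0% to 12%, most likely reported once more as a limit.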

Compound 4, a percentage reported as inhibition, at one concentration (the size of the read-out at that concentration, not a potency): < 5%
Compound 4 ended at the assay's limit; the forecaster's own chance of this, stated with the estimate: 80%; the middle value is on the limit's open side.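

Compound 4 gives < 5% in this assay, a limit of the assay and not a number. The steps to compound 4 from compound 1 and from compound 2 therefore cannot be read: the limit of < 5% in this assay, at which 4 of the 4 values shown sit.

The compounds shown leave open whether exchanging this aromatic arm changes the inhibition at all.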